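A pyridine in place of the thiazole on the amide

This account rests on a few compounds, and the source may have more. Where it says the series, first, only, none or still open, it means among the compounds named here.

In a functional assay on MDA-MB-231 cells (Homo sapiens) for antiproliferative activity, read by MTT assay, with stated times of 72 h and 4 h (on this read-out lower numbers stand for stronger inhibition and higher numbers for weaker inhibition), compound 1 `Cc1nc(C(=O)Nc2ccc(Cl)c(-c3nnc4c(Cl)cccn34)c2)cs1` reaches only a limit of the assay, > 100000 nM. Compound 2 `O=C(Nc1ccc(Cl)c(-c2nnc3c(Cl)cccn23)c1)c1c(F)cccc1Cl` likewise stops at a limit, giving > 100000 nM in this assay. Compound 3 `O=C(Nc1ccc(Cl)c(-c2nnc3c(Cl)cccn23)c1)c1ccccc1Cl` is the only one of the three with a number, 59900 nM in this assay. The step that the two limits leave unreadable from compound 1 to compound 2 is thus unreadable, while an at least 1.6-fold lower number from compound 1 to compound 3 (0.22 log units; that floor lies within the scatter) and an at least 1.6-fold lower number from compound 2 to compound 3 (0.22 log units; that floor lies within the scatter) give only floors within the scatter; the limit of > 100000 nM in this assay, at which 2 of the 3 values shown sit, caps what the set can say. Compound 4 `O=C(Nc1ccc(Cl)c(-c2nnc3c(Cl)cccn23)c1)c1ccccn1` has not been measured; it differs from compound 1 by pyridin-2-yl in place of 2-methyl-1,3-thiazol-4-yl on a carbonyl carbon. The measured steps that bear on this change are the two other replacements on the same carbonyl carbon, a step that the two limits leave unreadable from compound 1 to compound 2 and an at least 1.6-fold lower number from compound 1 to compound 3 (0.22 log units; that floor lies within the scatter), one unreadable and one a floor within the scatter, and neither shows a step beyond the scatter. The expectation for compound 4 is therefore no step beyond the scatter, an at least 1.1-fold lower number from compound 1 to compound 4 (0.04 log units; that floor lies within the scatter), with a good chance of another limit. The estimated value for compound 4 in this assay is 90000 nM, ranging from 30000 nM to 300000 nM.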

Compound 4, half-maximal inhibitory concentration: 92000 nM
Estimate against measurement, compound 4: 1.0-fold (0.01 log units) below; measured number inside the range.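

With pyridin-2-yl on the carbonyl carbon, compound 4 gives the set a second true number, so one replacement at this position can now be read in full: a 1.5-fold higher number from compound 3 to compound 4 (0.19 log units; within the scatter). Against the other two compounds only floors can be given, an at least 1.0-fold lower number from compound 1 to compound 4 (0.03 log units; that floor lies within the scatter) and an at least 1.0-fold lower number from compound 2 to compound 4 (0.03 log units; that floor lies within the scatter), so none of the replacements that can be read at this position shows a step beyond the scatter. Compound 1 and compound 2 remain at a limit of the assay, which still caps the comparison: the limit of > 100000 nM in this assay, at which 2 of the 4 values shown sit.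

The compounds shown leave open whether any group on this carbonyl carbon can produce a step beyond the scatter in this assay. All the groups shown there are aromatic rings, so a morpholine, a carboxylic acid or a longer alkyl chain at this position remains an open question.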